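The compounds below may be only part of what the source reports. "The series", "measured", "known", "first", "only" and "open" are said of these compounds alone.

Four close relatives share one core and differ at two places. Compound 2 `O=C(/C=C\Nc1ccc2[nH]ccc2c1)c1nc(-c2ccc(C(F)(F)F)cc2)n2ccccc12` carries a trifluoromethyl group on an aromatic carbon and a 1H-indol-5-yl group on an amine nitrogen; in a functional assay on B16-F10 cells (Mus musculus) for cytotoxicity, read by MTT assay, with a stated time of 48 h (a lower number here means a stronger inhibitor, a higher number a weaker inhibitor), compound 2 gives 18200 nM. Compound 1 `COc1ccc(-c2nc(C(=O)/C=C\Nc3ccc4[nH]ccc4c3)c3ccccn23)cc1` differs from it by methoxy in place of trifluoromethyl on an aromatic carbon; in this assay compound 1 gives 5120 nM, so that a 3.6-fold lower number from compound 2 to compound 1 (0.55 log units; beyond the scatter). Compound 3 `O=C(/C=C\Nc1ccc(F)cc1)c1nc(-c2ccc(C(F)(F)F)cc2)n2ccccc12` keeps the trifluoromethyl group but differs from compound 2 by 4-fluorophenyl in place of 1H-indol-5-yl on an amine nitrogen. For compound 3, this assay reports only a limit, > 30000 nM, which is the limit of > 30000 nM in this assay, at which 1 of the 3 values shown sits. Accordingly an at least 1.6-fold higher number from compound 2 to compound 3 (0.21 log units; that floor lies within the scatter). Compound 4 `COc1ccc(-c2nc(C(=O)/C=C\Nc3ccc(F)cc3)c3ccccn23)cc1`, not yet measured, differs from compound 3 by methoxy in place of trifluoromethyl on an aromatic carbon, the same change as from compound 2 to compound 1, made at the same place. The step from compound 3 to compound 4 in this assay is expected to resemble the earlier one, where a 3.6-fold lower number from compound 2 to compound 1 (0.55 log units; beyond the scatter), and is estimated as an at least 2.0-fold lower number from compound 3 to compound 4 (0.30 log units; that floor lies within the scatter), resting on compound 1 and compound 2 and on compound 3 giving only a limit. Compound 4 is therefore expected to give about 15000 nM, most likely between 6000 nM and 50000 nM.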

Compound 4, half-maximal inhibitory concentration: > 30000 nM
Compound 4: only a limit was reported; the forecaster's own chance of this, stated with the estimate: 35%; middle value at least 2.0-fold (0.30 log units) away from the limit.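

In this assay compound 4 gives > 30000 nM, which is a limit and not a number, and such limits now mark a large share of this small set: the limit of > 30000 nM in this assay, at which 2 of the 4 values shown sit.

The step that the two limits leave unreadable from compound 3 to compound 4 therefore cannot be read, so nothing shows whether the lower number seen on changing trifluoromethyl to methoxy in the indole-bearing pair carries over to the 4-fluorophenyl core, while the other change, 4-fluorophenyl in place of 1H-indol-5-yl, can be read with methoxy present as an at least 5.8-fold higher number from compound 1 to compound 4 (0.76 log units; beyond the scatter). Whether that second change has the same size on both cores stays undecided: the same change on two cores in this assay, an at least 1.6-fold higher number (0.21 log units; that floor lies within the scatter) from compound 2 to compound 3 and an at least 5.8-fold higher number (0.76 log units; beyond the scatter) from compound 1 to compound 4; the limit leaves it open whether they differ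

The compounds shown leave open whether the 1H-indol-5-yl group itself matters or whether another group on the amine nitrogen, such as a plain phenyl or a pyridine ring, would serve as well. They also leave open how a hydroxyl group or a chlorine atom would fare in place of methoxy on the aromatic ring.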